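The source may hold more compounds than are shown below. What is called first, only, known or untested is meant among the compounds shown, and "the series" means these compounds.

Measured in an ADME assay on H1-HeLa cells (Homo sapiens) for cytotoxicity, read by MTT assay, with a stated time of 3 days; on this read-out lower numbers stand for higher toxicity in this test and higher numbers for lower toxicity in this test:

compound 1 `CCOC(=O)c1sc2cc(Oc3ccnc(C(=O)NC)c3)ccc2c1C`: 50900 nM
compound 2 `CCOC(=O)c1sc2cc(Oc3ccnc(C(=O)NC)c3)ccc2c1CC`: 35200 nM

Going by the values given here, compound 1 stands level with compound 2, the only other measured compound, within the scatter. Among the compounds with values here, the one measured step is a 1.4-fold lower number from compound 1 to compound 2 (0.16 log units; within the scatter), and it places methyl in place of hydrogen on a saturated chain carbon bound to an aromatic carbon.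

Compound 3 `CNC(=O)c1cc(Oc2ccc3c(C)c(C(=O)O)sc3c2)ccn1` departs from compound 1 elsewhere: hydrogen in place of ethyl on an oxygen next to a carbonyl group. This is hydrogen in place of ethyl on an oxygen next to a carbonyl group, or ethoxycarbonyl to carboxy. Within the data shown here, no measured step covers this change, so the data give it no size and the one step above bears on it only loosely. A modestly higher number in this assay is assumed, without measured support, and the range is kept wide. The expected change is a 1.4-fold higher number from compound 1 to compound 3 (0.14 log units; within the scatter). For compound 3 the estimated value is 70000 nM, with an expected range of 30000 nM to 170000 nM.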

Compound 3, half-maximal cytotoxic concentration: > 100000 nM
Compound 3 ended at the assay's limit; the forecaster's own chance of this, stated with the estimate: 35%; at least 1.4-fold (0.15 log units) between middle value and limit.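

In this assay, the change from ethoxycarbonyl to carboxy gives an at least 1.9-fold higher number from compound 1 to compound 3 (0.29 log units; that floor lies within the scatter). Going by these compounds alone, this is the first look at the oxygen next to the carbonyl group, as the earlier step touched only a saturated chain carbon bound to an aromatic carbon. The reading for compound 3 is a limit of the assay, not a number, so the change has only a floor and its true size stays unknown: the limit of > 100000 nM in this assay, at which 1 of the 3 values shown sits.

On these data alone, what remains open is how far past that limit compound 3 lies, and whether the same change on compound 2 would read alike. Also open, as far as these compounds go, is how a longer chain on this oxygen, or an amine in place of the ethoxy, would read in this assay.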